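The compounds below may be only part of what the source reports. "The series", "measured", "known", "first", "only" and "open" are said of these compounds alone.

Measured in a functional assay on HCT-116 cells (Homo sapiens) for antiproliferative activity, with a stated time of 72 h; on this read-out lower numbers stand for stronger inhibition and higher numbers for weaker inhibition:
Compound 1 `Cc1[nH]c2ccccc2c1C1=CCC(NC(=O)c2ccc(OCC(=O)NO)cc2)CC1`: > 5000 nM
Compound 2 `Cc1[nH]c2ccccc2c1C1=CCN(C(=O)c2ccc(OCC(=O)NO)cc2)CC1`: > 5000 nM
Compound 3 `O=C(COc1ccc(C(=O)N2CC=C(c3c[nH]c4ccc(F)cc34)CC2)cc1)NO`: > 5000 nM

Compound 3 is known only by a limit of the assay, > 5000 nM, and not by a number. All three compounds stand at the limit of > 5000 nM in this assay, at which 3 of the 3 values shown sit.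

Compound 4 `O=C(COc1ccc(C(=O)N2CC=C(c3c[nH]c4cccc(F)c34)CC2)cc1)NO` carries 4-fluoro-1H-indol-3-yl in place of 5-fluoro-1H-indol-3-yl on a double-bonded ring carbon.

Going by the values given here, the one measured step bearing on this change, a step that the two limits leave unreadable from compound 2 to compound 3, alters the same group, but its size cannot be read. No direction can therefore be drawn from it, and no step beyond the scatter is expected in this assay. The expected step is a step that the limit leaves unreadable from compound 3 to compound 4. For compound 4 the estimate is 7000 nM, with an expected range from 2500 nM to 20000 nM.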

Compound 4, half-maximal inhibitory concentration: 1410 nM
Beside the measured number, compound 4's estimate is 5.0-fold (0.70 log units) above it; the measured number lies below the stated range.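

In this assay, 4-fluoro-1H-indol-3-yl in place of 5-fluoro-1H-indol-3-yl gives an at least 3.5-fold lower number from compound 3 to compound 4 (0.54 log units; beyond the scatter), so the placing of the fluorine alone separates two compounds that have the same atoms. Set against 2-methyl-1H-indol-3-yl, the same group gives an at least 3.5-fold lower number from compound 2 to compound 4 (0.54 log units; beyond the scatter). Compound 4 is the only compound shown that has a number rather than a limit: the limit of > 5000 nM in this assay, at which 3 of the 4 values shown sit.

Going by these compounds, compound 2 and compound 3 are known only by limits, so the full size of both steps stays open and the step between them cannot be read. Also open, on these data alone, is how 4-chloro-1H-indol-3-yl or 4-methoxy-1H-indol-3-yl would compare with 4-fluoro-1H-indol-3-yl.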